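The source may report more compounds than this note shows. Statements on the series, on what has been measured and on what is new or still open speak of the compounds shown alone.

Measured so far:
compound 1 `COc1cc(-c2cc(/C=C/C(=O)c3ccc(N)cc3)[nH]n2)cc(OC)c1OC`: 1860 nM in a functional assay on SK-MEL-28 cells (Homo sapiens) for inhibition, read by sulforhodamine B assay, with a stated time of 48 h; on this read-out higher numbers stand for weaker inhibition of growth and lower numbers for stronger inhibition of growth
compound 2 `COc1ccc(C(=O)/C=C/c2cc(-c3cc(OC)c(OC)c(OC)c3)n[nH]2)cc1`: 2120 nM in this assay

Within the data shown here, compound 2 gives the higher of the two numbers in this assay, with compound 1 as its only neighbour; the step of a 1.1-fold higher number from compound 1 to compound 2 (0.06 log units; within the scatter) lies within the scatter, so the two cannot be ordered. Compound 3 `COc1cc(-c2cc(/C=C/C(=O)c3ccc(F)c(F)c3)[nH]n2)cc(OC)c1OC` has not yet been measured there. It differs from compound 2 by 3,4-difluorophenyl in place of 4-methoxyphenyl on a carbonyl carbon. Among the measured compounds shown here, the one measured step, a 1.1-fold higher number from compound 1 to compound 2 (0.06 log units; within the scatter), also swaps a single group on an aromatic carbon of the ring at the carbonyl and moved nothing beyond the scatter. For the measured compounds named here, no measured step covers fluorine entering that ring, nor a second substituent on it, so the change is only loosely covered. The working expectation is a step of a 1.2-fold higher number from compound 2 to compound 3 (0.07 log units; within the scatter), no change beyond the scatter. Compound 3 is accordingly estimated at 2500 nM, with a range from 900 nM to 7000 nM.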

Compound 3, concentration for 50% growth inhibition: 5310 nM
For compound 3 the middle estimate is 2.1-fold (0.33 log units) below the measured one, within the range that was stated.
By their numbers in this assay, from the lowest: compounds 1 and 2 (each within the scatter of the next); then compound 3.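

In this assay, the group on the carbonyl carbon can move the number beyond the scatter: 3,4-difluorophenyl in place of 4-methoxyphenyl gives a 2.5-fold higher number from compound 2 to compound 3 (0.40 log units; beyond the scatter), and the same group in place of 4-aminophenyl gives a 2.9-fold higher number from compound 1 to compound 3 (0.46 log units; beyond the scatter). Among these compounds, compounds 1 and 2 alone could not be ordered, so this is the first sign that the aryl group at this place matters, and both steps run towards weaker inhibition of growth, though modestly. No available evidence bears on why the difluorinated compound differs from the other two.

As far as these compounds go, it remains open whether a single fluorine on that ring would give a step of the same size as the pair. Also open, from the compounds shown here alone, is where a chlorine, a hydroxyl group or a carboxylic acid on that ring would fall relative to these three compounds.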